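A Carboxy Group in Place of Chloro on the Ring

A few compounds are considered here, and "the series" means these few. Any claim that something is new, unique, unknown or untested is made for them only; others in the source may bear on it.

Compound 1 `CCC(COc1ccccc1)OC(=O)NCc1ccccc1`: in an assay for inhibition of zeta-carotene desaturase, chloroplastic/chromoplastic (Capsicum annuum), using a Dixon plot, with a stated time of 8 h (a lower number here means a stronger inhibitor, a higher number a weaker inhibitor), compound 1 gives > 100000 nM, which is a limit of the assay, not a number.
Compound 2 `CCC(COc1cccc(Cl)c1)OC(=O)NCc1ccccc1`: in this assay compound 2 gives > 100000 nM, likewise a limit.
Compound 3 `CCC(COc1cccc([N+](=O)[O-])c1)OC(=O)NCc1ccccc1`: in this assay compound 3 gives > 100000 nM, also a limit.

Compound 2 therefore stands exactly where the other two measured compounds stand, at a limit rather than at a number, a point summed up by the limit of > 100000 nM in this assay, at which 3 of the 3 values shown sit. Going by the values given here, no measured compound in this set has a readable value, so none can be called stronger or weaker than another.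

Compound 4 `CCC(COc1cccc(C(=O)O)c1)OC(=O)NCc1ccccc1` differs from compound 2 in one place: carboxy in place of chloro on an aromatic carbon. The measured steps that touch compound 2 are a step that the two limits leave unreadable from compound 1 to compound 2 and a step that the two limits leave unreadable from compound 2 to compound 3; the remaining one, a step that the two limits leave unreadable from compound 1 to compound 3, is no more informative. None of them yields a size or a direction, so there is no basis for expecting a step beyond the scatter in this assay, and none for ruling one out either.

Compound 4 is thus expected to give about 150000 nM, within 30000 nM to 1000000 nM, most probably reported once more as a limit. The step this estimate means, a step that the limit leaves unreadable from compound 2 to compound 4, is expected to lie within the scatter.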

Compound 4, half-maximal inhibitory concentration: > 100000 nM
Compound 4 ended at the assay's limit (the forecaster's own chance of this, stated with the estimate: 85%); the middle value does not contradict the limit.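

Compound 4 stands at a limit of the assay rather than at a number, and the steps to it from compound 1, compound 2 and compound 3 cannot be read: the limit of > 100000 nM in this assay, at which 4 of the 4 values shown sit.

The compounds shown leave open whether any change to the shared core would give a readable value in this assay, and which groups would matter.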